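Removing the methoxymethyl group from compound 3

The source may report more compounds than this note shows. Statements on the series, on what has been measured and on what is new or still open speak of the compounds shown alone.

Measured so far in a physicochemical assay for solubility, in phosphate buffer, at pH 7.4; on this read-out lower numbers stand for lower solubility and higher numbers for higher solubility:
- compound 1 `OC1CN(c2nccnc2OC2CN(c3ccc4ccccc4n3)C2)C1` gives 41000 nM
- compound 2 `OCC1CCN(c2nccnc2OC2CN(c3ccc4ccccc4n3)C2)C1` gives 167000 nM
- compound 3 `COCC1CCN(c2nccnc2OC2CN(c3ccc4ccccc4n3)C2)CC1` gives 53000 nM

Compound 3 has one neighbour inside the scatter, a 1.3-fold higher number from compound 1 to compound 3 (0.11 log units; within the scatter), and one outside it, a 3.2-fold lower number from compound 2 to compound 3 (0.50 log units; beyond the scatter). Compound 4 `c1ccc2nc(N3CC(Oc4nccnc4N4CCCCC4)C3)ccc2c1` differs from compound 3 by hydrogen in place of methoxymethyl on a saturated ring carbon, with hydrogen in place of methoxymethyl on a saturated ring carbon. Among the compounds with values here, no measured step removes a substituent outright. The measured steps only exchange one substituted ring for another, and with a 4.1-fold higher number from compound 1 to compound 2 (0.61 log units; beyond the scatter) as the largest, a modest step to a lower number is expected. The estimated step is a 3.5-fold lower number from compound 3 to compound 4 (0.55 log units; beyond the scatter), and its direction remains tentative. The estimated value for compound 4 is 15000 nM, expected between 4000 nM and 50000 nM once measured.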

Compound 4, solubility: < 1000 nM
Compound 4: only a limit was reported; the forecaster's own chance of this, stated with the estimate: 5%; middle value at least 15-fold (1.17 log units) from the limit.
By their numbers in this assay, from the lowest: compounds 1 and 3 (each within the scatter of the next); then compound 2. At a limit, below all of these: compound 4.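

In this assay, removing a substituent outright from this saturated ring carbon does far more than exchanging one substituted ring for another: an at least 53-fold lower number from compound 3 to compound 4 (1.72 log units; beyond the scatter). The other two steps to piperidin-1-yl are also large, an at least 160-fold lower number from compound 2 to compound 4 (2.22 log units; beyond the scatter) and an at least 41-fold lower number from compound 1 to compound 4 (1.61 log units; beyond the scatter), so compounds 1, 2 and 3 all stand well clear of compound 4 despite their different rings. Compound 4 sits at a limit, so these steps are bounds only: the limit of < 1000 nM in this assay, at which 1 of the 4 values shown sits.

From the compounds shown here alone, whether a methyl group or an amine on this ring carbon would match methoxymethyl remains open. How far compound 4 truly lies past its limit is also unresolved.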